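Two Sulfonamides at the Assay Limit and a Biaryl Successor

The source may hold more compounds than are shown below. What is called first, only, known or untested is meant among the compounds shown, and "the series" means these compounds.

Compound 1, `CC1CCN(C2CCN(S(=O)(=O)c3ccc(C(C)(C)C)cc3)CC2)CC1`: in a functional assay on DLD-1 cells (Homo sapiens) for antiproliferative activity, read by CellTiter-Glo, with a stated time of 72 h (a higher number here means a weaker inhibitor, a lower number a stronger inhibitor), compound 1 gives > 5000 nM, which is a limit of the assay and not a number.
Compound 2, `COC(=O)c1ccc(S(=O)(=O)N2CCC(N3CCC(C)CC3)CC2)cc1`: in this assay compound 2 gives > 5000 nM, again a limit rather than a number.

Compound 2 therefore stands nowhere definite on the numbers shown; it sits, like the only other measured compound, at the limit of > 5000 nM in this assay, at which 2 of the 2 values shown sit. Within the data shown here, the one measured step, a step that the two limits leave unreadable from compound 1 to compound 2, cannot be read in size or direction because both of its ends are limits (the limit of > 5000 nM in this assay, at which 2 of the 2 values shown sit). Compound 3, `COc1ccc(-c2ccc(S(=O)(=O)N3CCC(N4CCC(C)CC4)CC3)cc2)cc1`, differs from compound 2 by 4-methoxyphenyl in place of methoxycarbonyl on an aromatic carbon. Among the measured compounds shown here, no measured step gives a readable size for a change of this kind, so nothing in the data says whether this step should be large, small or absent beyond the scatter. With both known values at the limit, the most that can be said is that compound 3 is expected, more likely than not, to return another limit. Compound 3 is therefore estimated at 5000 nM, within a range from 1500 nM to 20000 nM. The step expected here is a number no higher from compound 2 to compound 3 (the limit leaves the size open), an estimate that rests on no measured size.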

Compound 3, half-maximal inhibitory concentration: 263 nM
Compound 3: the middle estimate sits 19-fold (1.28 log units) above what was measured, and the stated range ends above it.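

The position on the aromatic carbon, which the two limits had left unreadable, now gives a readable result in this assay: 4-methoxyphenyl in place of methoxycarbonyl gives an at least 19-fold lower number from compound 2 to compound 3 (1.27 log units; beyond the scatter), and 4-methoxyphenyl in place of tert-butyl gives an at least 19-fold lower number from compound 1 to compound 3 (1.27 log units; beyond the scatter). The shared core is thus not tied to the limit, as a change at this one place alone brings a measured number, and what enters carries one six-membered aromatic ring of carbon only, whereas the methoxycarbonyl that leaves has no ring. Both steps give only a minimum size rather than an exact one, because each starts from a limit: the limit of > 5000 nM in this assay, at which 2 of the 3 values shown sit.

The compounds shown do not separate the contribution of the added ring from that of the methoxy group on it, as neither an unsubstituted phenyl nor a phenyl bearing a fluorine or an amine in place of the methoxy group stands among them. They also leave open how the number would respond to a carboxylic acid or a longer chain at this place, and whether a change elsewhere in the core would add to this step.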